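The source may hold more compounds than are shown below. What is called first, only, known or untested is meant among the compounds shown, and "the series" means these compounds.

Compound 3 `COc1ccc(/C=C\C(=O)O)c(OCc2cn(-c3ccc(CO)cc3)nn2)c1CC=C(C)C` stands second highest of the three compounds measured in a functional assay on NCI-H322 cells (Homo sapiens) for cytotoxicity, read by MTT assay, with a stated time of 24 h (a lower number here means a stronger inhibitor, a higher number a weaker inhibitor), where compound 3 gives 27100 nM. Its nearest neighbour is compound 1 `COc1ccccc1-n1cc(COc2c(/C=C\C(=O)O)ccc(OC)c2CC=C(C)C)nn1`, for which the same assay records 41500 nM; the step of a 1.5-fold lower number from compound 1 to compound 3 (0.19 log units; within the scatter) stays within the scatter. Compound 2 `COc1ccc(/C=C\C(=O)O)c(OCc2cn(-c3ccccc3C#N)nn2)c1CC=C(C)C` gives 14400 nM, and the step of a 1.9-fold higher number from compound 2 to compound 3 (0.27 log units; within the scatter) is likewise within the scatter, so no order among these three compounds can be claimed.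

Compound 4 `COc1ccc(/C=C\C(=O)O)c(OCc2cn(-c3cccc(C#N)c3)nn2)c1CC=C(C)C` differs from compound 3 in one place: 3-cyanophenyl in place of 4-(hydroxymethyl)phenyl on an aromatic nitrogen.

Going by the values given here, two measured steps bear on this change. The step of a 2.9-fold lower number from compound 1 to compound 2 (0.46 log units; beyond the scatter) shows a nitrile on an aromatic carbon giving a modestly lower number than a methoxy, and the step of a 1.9-fold higher number from compound 2 to compound 3 (0.27 log units; within the scatter) shows that moving from a 2-cyanophenyl to a 4-(hydroxymethyl)phenyl on the aromatic nitrogen changed little. Since compound 4 carries a 3-cyanophenyl, it is expected to land near compound 2, with the step of a 1.6-fold lower number from compound 3 to compound 4 (0.20 log units; within the scatter) expected to be small and downward, close to the edge of the scatter.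

Compound 4 is therefore estimated at 17000 nM in this assay, with a range from 8000 nM to 36000 nM.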

Compound 4, half-maximal inhibitory concentration: 26500 nM
For compound 4 the middle estimate is 1.6-fold (0.19 log units) below the measured one; the measured number falls inside the stated range.
By their numbers in this assay, from the lowest: compounds 2, 4, 3 and 1 (each within the scatter of the next, the first and the last beyond it).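

Replacing the 4-(hydroxymethyl)phenyl with 3-cyanophenyl on the aromatic nitrogen gives no readable change in this assay, despite removing the hydrogen-bond donor of the hydroxymethyl group: a 1.0-fold lower number from compound 3 to compound 4 (0.01 log units; within the scatter). The position of the nitrile cannot be resolved either, since a 1.8-fold higher number from compound 2 to compound 4 (0.26 log units; within the scatter), while a 1.6-fold lower number from compound 1 to compound 4 (0.19 log units; within the scatter) shows that 3-cyanophenyl does not repeat the separation beyond the scatter seen with 2-cyanophenyl, a 2.9-fold lower number from compound 1 to compound 2 (0.46 log units; beyond the scatter), so a nitrile on this ring does not by itself set compound 4 apart from compound 1. Nothing available here offers an explanation for how closely these aryl groups read in this assay.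

Among the compounds shown, only compound 1 and compound 2 are separated beyond the scatter, so it remains open whether any group on this ring can shift the number further. An amine or a carboxylic acid on the ring, or a longer chain carrying the hydroxyl in place of the hydroxymethyl, would test whether this position responds at all beyond the modest separation seen so far.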